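Methoxy in place of chloro on the second aryl ring

The source may hold more compounds than are shown below. What is called first, only, known or untested is meant among the compounds shown, and "the series" means these compounds.

Compound 1, `Fc1ccc(C2CC(c3ccc(Cl)cc3)=NN2c2ccc(-c3ccccc3)nn2)cc1`, gives 3750 nM in a functional assay on MCF7 cells (Homo sapiens) for antiproliferative activity, read by MTT assay, with a stated time of 24 h; on this read-out higher numbers stand for weaker inhibition and lower numbers for stronger inhibition.
Compound 2, `COc1ccc(C2CC(c3ccc(Cl)cc3)=NN2c2ccc(-c3ccccc3)nn2)cc1`, gives 100000 nM in this assay.
Compound 3, `COc1ccc(C2CC(c3ccc(Cl)cc3)=NN2c2ccc(-c3ccccc3)nn2)c(OC)c1`, reaches only a limit of the assay, > 100000 nM, in this assay.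

Compound 1 stands lowest of the two numbers shown; its nearest neighbour is compound 2, reached by a 27-fold higher number from compound 1 to compound 2 (1.43 log units; beyond the scatter). From compound 1 to compound 3 the step is an at least 26-fold higher number from compound 1 to compound 3 (1.42 log units; beyond the scatter). Compound 3 sits at the limit of > 100000 nM in this assay, at which 1 of the 3 values shown sits.

Compound 4, `COc1ccc(C2=NN(c3ccc(-c4ccccc4)nn3)C(c3ccc(F)cc3)C2)cc1`, differs from compound 1 by methoxy in place of chloro on an aromatic carbon. Among the measured compounds shown here, no measured step alters this chloro itself. The one that bears on it is the step from compound 1 to compound 2, in which a methoxy replaced a halogen on an aromatic carbon of the other ring and produced a 27-fold higher number from compound 1 to compound 2 (1.43 log units; beyond the scatter). On that basis the author expects a clearly higher number for compound 4 in this assay, though the size remains uncertain. Compound 4 is expected to give about 30000 nM, between 8000 nM and 100000 nM. For compound 4 this means an expected step of an 8.0-fold higher number from compound 1 to compound 4 (0.90 log units; beyond the scatter).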

Compound 4, half-maximal inhibitory concentration: 20000 nM
Compound 4: middle estimate off by 1.5-fold (0.18 log units), on the high side, and the stated range covers the measured number.
By their numbers in this assay, from the lowest: compound 1; then compound 4; then compound 2.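

In this assay there is a 5.3-fold higher number from compound 1 to compound 4 (0.73 log units; beyond the scatter) and this is the first change shown on the ring that carries the chloro, so the 4-chlorophenyl to 4-methoxyphenyl exchange lowers activity at this position too. The step is nevertheless smaller than a 27-fold higher number from compound 1 to compound 2 (1.43 log units; beyond the scatter) on the other ring, so the two methoxy exchanges do not cost the same, although chloro leaves in one and fluoro in the other. Compound 4 also gives a number that can be read, which places this exchange on a scale rather than at a limit of the assay.

The compounds shown leave open how an amine, a hydroxyl or a methyl would fare in place of this chloro. Nothing given here explains the step.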